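The compounds below may be only part of what the source reports. "The series", "measured", "known", "first", "only" and "open" are said of these compounds alone.

Compound 2 `COc1cc2c(Oc3ccc(NC(=O)c4nn(-c5ccccc5F)c(=O)c5ccccc45)cc3F)ccnc2cc1OCCCN1CCCCC1` is one of three close relatives tested in a functional assay on MKN-45 cells (Homo sapiens) for cytotoxicity, read by MTT assay, with a stated time of 72 h; on this read-out lower numbers stand for stronger inhibition and higher numbers for weaker inhibition: compound 2 gives 350 nM, compound 1 `COc1cc2c(Oc3ccc(NC(=O)c4nn(-c5ccccc5)c(=O)c5ccccc45)cc3F)ccnc2cc1OCCCN1CCCCC1` gives 590 nM, and compound 3 `COc1cc2c(Oc3ccc(NC(=O)c4nn(-c5ccc(Br)cc5)c(=O)c5ccccc45)cc3F)ccnc2cc1OCCCN1CCCCC1` gives 500 nM. Compound 2 sits within the scatter of both neighbours, since the steps run a 1.7-fold lower number from compound 1 to compound 2 (0.23 log units; within the scatter) and a 1.4-fold higher number from compound 2 to compound 3 (0.15 log units; within the scatter), and the remaining step is a 1.2-fold lower number from compound 1 to compound 3 (0.07 log units; within the scatter). Compound 4 `COc1cc2c(Oc3ccc(NC(=O)c4nn(-c5ccccc5F)c(=O)c5ccccc45)cc3F)ccnc2cc1OCCCN1CCC(C)CC1` differs from compound 2 by methyl in place of hydrogen on a saturated ring carbon. Among the measured compounds shown here, none of the measured steps touches that saturated ring; all three alter the aromatic group on the ring nitrogen, and all three stayed within the scatter. For the measured compounds named here, with no step bearing on this change, no shift beyond the scatter is expected in this assay, so the expected step is no change at the digits printed from compound 2 to compound 4 (within the scatter). Compound 4 is therefore estimated at 350 nM, with a range from 150 nM to 850 nM.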

Compound 4, half-maximal inhibitory concentration: 260 nM
Beside the measured number, compound 4's estimate is 1.3-fold (0.13 log units) above it, and the stated range covers the measured number.
By their numbers in this assay, from the lowest: compounds 4, 2, 3 and 1 (each within the scatter of the next, the first and the last beyond it).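

Among the compounds shown here, the earlier compounds varied only the aromatic group on the ring nitrogen, so compound 4 gives the first reading on the piperidin-1-yl ring. In this assay the change to 4-methylpiperidin-1-yl gives a 1.3-fold lower number from compound 2 to compound 4 (0.13 log units; within the scatter) and so this ring carbon carries a methyl with no shift beyond the scatter. Nothing shown explains this result.

On these data alone, whether a longer chain such as propyl or a phenyl ring at this carbon would also stay within the scatter remains open. So does the effect of an amine or a carboxylic acid there.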